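Fluoro removal in two cores: cytotoxicity on Vero cells

The source may hold more compounds than are shown below. What is called first, only, known or untested is meant among the compounds shown, and "the series" means these compounds.

The series holds two cores. Compound 1 `CCO/N=C1\C(=O)N(CCCCOc2ccc3oc(-c4ccc(OC)cc4)c(C(=O)OCC)c3c2)c2ccc(F)cc21` carries a fluoro group on its core; in an ADME assay on Vero cells (Chlorocebus sabaeus) for cytotoxicity, read by MTT assay, with a stated time of 72 h (a lower number here means that less compound is tolerated, a higher number that more compound is tolerated), compound 1 gives 32 ug/mL. The other core appears in compound 2 `CCOC(=O)c1c(-c2ccc(OC)cc2)oc2ccc(OCCCCCCN3C(=O)C(=O)c4ccccc43)cc12` and compound 3 `CCOC(=O)c1c(-c2ccc(OC)cc2)oc2ccc(OCCCCCCN3C(=O)C(=O)c4cc(F)ccc43)cc12`. In this assay compound 2 gives 256 ug/mL, and compound 3 gives 1020 ug/mL. How the two cores differ is not broken down here.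

Within the second core one change is measured: hydrogen in place of fluoro on an aromatic carbon This gave a 4.0-fold lower number from compound 3 to compound 2 (0.60 log units; beyond the scatter).

Compound 4 `CCO/N=C1\C(=O)N(CCCCOc2ccc3oc(-c4ccc(OC)cc4)c(C(=O)OCC)c3c2)c2ccccc21` is not yet measured. It arises from compound 1 by the same change: hydrogen in place of fluoro on an aromatic carbon The place of the change is described in the same words for both pairs, so the change is taken as the same.

For compound 4 the expected step is a 2.7-fold lower number from compound 1 to compound 4 (0.43 log units; beyond the scatter), which rests on the single measured case, namely a 4.0-fold lower number from compound 3 to compound 2 (0.60 log units; beyond the scatter) in the other core. A single case in a different core is thin support, so the range is kept wide. Compound 4 is therefore estimated at 12 ug/mL in this assay, with a span from 4 ug/mL to 40 ug/mL.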

Compound 4, half-maximal cytotoxic concentration: 64 ug/mL
For compound 4 the middle estimate is 5.3-fold (0.73 log units) below the measured one; measured number above the stated range.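

In this assay, hydrogen in place of fluoro on the core of compound 1 gives a 2.0-fold higher number from compound 1 to compound 4 (0.30 log units; within the scatter), a step that stays within the usual scatter, whereas the same change on the other core goes beyond it. The step therefore did not carry over unchanged from one core to the other in this series: the same change on two cores in this assay, a 4.0-fold lower number (0.60 log units; beyond the scatter) from compound 3 to compound 2 and a 2.0-fold higher number (0.30 log units; within the scatter) from compound 1 to compound 4, 8.0-fold (0.90 log units) apart, beyond the scatter of two such steps. This rests on a single pair per core, so it warns against using the step from one core as a forecast for the other, but it does not show what sets the two cores apart or how the change would behave on a further core.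

The compounds shown leave open which part of the two cores goes with the different steps, since no pair here separates the linking chain from the other differences between them. Also open, going by these compounds, is how a chloro group or a nitrile on the same aromatic carbon would compare on either core.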